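The source may report more compounds than this note shows. Statements on the series, on what has been measured and on what is new or still open speak of the compounds shown alone.

In a functional assay on 3T3-L1 cells (Mus musculus) for inhibition, with a stated time of 20 min, tested at 20 uM (on this read-out lower numbers stand for less inhibition and higher numbers for more inhibition at the one concentration tested (going by the name of the read-out)), compound 3 `Cc1ccc(S(=O)(=O)N(Cc2cn(Cc3ccccc3)nn2)Cc2cn(S(=O)(=O)c3ccc(C)cc3)c3ccccc23)cc1` gives 3.4%, the lowest of the three numbers shown, though compound 1 `COc1ccc(Cn2cc(CN(Cc3cn(S(=O)(=O)c4ccc(C)cc4)c4ccccc34)S(=O)(=O)c3ccc(C)cc3)nn2)c(OC)c1` with 7.6% sits within the usual scatter of it; compound 2 `Cc1ccc(S(=O)(=O)N(Cc2cn(Cc3cccc(F)c3F)nn2)Cc2cn(S(=O)(=O)c3ccc(C)cc3)c3ccccc23)cc1` gives 71.5%, and a number 68.1 percentage points lower from compound 2 to compound 3 (beyond the scatter). Compound 4 `COc1ccc(Cn2cc(CN(Cc3cn(S(=O)(=O)c4ccc(C)cc4)c4ccccc34)S(=O)(=O)c3ccc(C)cc3)nn2)cc1` differs from compound 3 by methoxy in place of hydrogen on an aromatic carbon. The step that bears on this is the one in which 2,4-dimethoxyphenyl gives way to phenyl, a number 4.2 percentage points lower from compound 1 to compound 3 (within the scatter). Returning a single methoxy is therefore expected to leave the number roughly where it is; the large change a number 63.9 percentage points higher from compound 1 to compound 2 (beyond the scatter) concerns 2,3-difluorophenyl and does not apply here. The estimate for compound 4 is 6%, between 0% and 20%. This means an expected step of a number 2.6 percentage points higher from compound 3 to compound 4 (within the scatter).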

Compound 4, a percentage reported as inhibition, at one concentration (the size of the read-out at that concentration, not a potency): 1%
The estimate for compound 4 lay 5 percentage points above the measured number, and the stated range covers the measured number.
By their numbers in this assay, from the lowest: compounds 4, 3 and 1 (each within the scatter of the next); then compound 2.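

In this assay, 4-methoxybenzyl gives a result close to that of plain benzyl (a number 2.4 percentage points lower from compound 3 to compound 4 (within the scatter)), and taking away the second methoxy of compound 1 also changes little (a number 6.6 percentage points lower from compound 1 to compound 4 (within the scatter)). A lone methoxy para to a large group therefore stays far from the 2,3-difluorophenyl result (a number 70.5 percentage points lower from compound 2 to compound 4 (beyond the scatter)). Nothing available here explains this difference.

From the compounds shown here alone, it remains open whether a single fluorine, a chlorine or a nitrile para to that large group would come closer to compound 2. It is also unclear whether one or both fluorines in compound 2 are needed for its high number.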